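Swapping fluoro for amino on the aromatic ring

A few compounds are considered here, and "the series" means these few. Any claim that something is new, unique, unknown or untested is made for them only; others in the source may bear on it.

In a functional assay on OVCAR-5 cells (Homo sapiens) for inhibition, with a stated time of 48 h, tested at 50 uM (on this read-out higher numbers stand for more inhibition of growth at the one concentration tested and lower numbers for less inhibition of growth), compound 3 `CC(C)=CCC[C@](C)(/C=C/c1ccc(O)cc1)/C=C/c1ccc(F)cc1` gives 29%, within the usual scatter of both compound 1 `COc1ccccc1/C=C/[C@@](C)(/C=C/c1ccc(O)cc1)CCC=C(C)C` at 38% and compound 2 `COc1ccc(/C=C/[C@@](C)(/C=C/c2ccc(O)cc2)CCC=C(C)C)cc1` at 20%. Compound 4 `CC(C)=CCC[C@@](C)(/C=C/c1ccc(N)cc1)/C=C/c1ccc(O)cc1` carries amino in place of fluoro on an aromatic carbon. Within the data shown here, no measured step makes this exact exchange. The closest puts fluoro in place of methoxy on an aromatic carbon, a number 9 percentage points higher from compound 2 to compound 3 (within the scatter), which stays within the scatter. Exchanging the whole substituted phenyl group gave a number 9 percentage points lower from compound 1 to compound 3 (within the scatter), also within the scatter. Only 4-methoxyphenyl in place of 2-methoxyphenyl went beyond it, a number 18 percentage points lower from compound 1 to compound 2 (beyond the scatter), and that is a different kind of change. The expected change in this assay is therefore none beyond the scatter, a number 1 percentage points lower from compound 3 to compound 4 (within the scatter). Compound 4 is estimated at 28%, within an expected range of 14% to 44%.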

Compound 4, percent growth inhibition at one concentration: 16%
For compound 4 the middle estimate is 12 percentage points above the measured one, within the range that was stated.
By their numbers in this assay, from the lowest: compounds 4, 2, 3 and 1 (each within the scatter of the next, the first and the last beyond it).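

Amino in place of fluoro, on this aromatic carbon para to a large group, gives a number 13 percentage points lower from compound 3 to compound 4 (beyond the scatter) in this assay, so this exchange shifts growth inhibition by more than the fluoro and methoxy exchange at the same place did. Amino in place of methoxy gives a number 4 percentage points lower from compound 2 to compound 4 (within the scatter), while the whole-group exchange of 4-aminophenyl for 2-methoxyphenyl gives a number 22 percentage points lower from compound 1 to compound 4 (beyond the scatter). Nothing measured here explains the step from fluoro to amino. The compounds shown leave open how a carboxylic acid or an acetamide on this same carbon would read.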